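Swapping a methoxy for a ring ether on two related cores

The source may report more compounds than this note shows. Statements on the series, on what has been measured and on what is new or still open speak of the compounds shown alone.

Compound 1, with the structure `C=C(C)C(=O)Nc1cc2c(N3CCc4ccccc43)ncnc2cc1OC`, is tested in a functional assay on MCF7 cells (Homo sapiens) for antiproliferative activity, read by MTT assay, with a stated time of 72 h (a higher number here means a weaker inhibitor, a lower number a stronger inhibitor), where compound 1 gives 11100 nM. Compound 2, `C=C(C)C(=O)Nc1cc2c(N3CCc4ccccc43)ncnc2cc1O[C@@H]1CCOC1`, carries the change oxolan-3-yl in place of methyl on an oxygen on an aromatic ring and gives 14700 nM in this assay; this change made a step of a 1.3-fold higher number from compound 1 to compound 2 (0.12 log units; within the scatter). Compound 3, `COc1cc2ncnc(N3CCCc4ccccc43)c2cc1NC(=O)C=C(C)C`, has a different core; the difference between the core of compound 1 and the core of compound 3 is not broken down here. In this assay compound 3 gives 6870 nM. Compound 4, `CC(C)=CC(=O)Nc1cc2c(N3CCCc4ccccc43)ncnc2cc1O[C@@H]1CCOC1`, is not yet measured and carries the same change on the core of compound 3, namely (oxolan-3-yl in place of methyl on an oxygen on an aromatic ring). Because the first such step was a 1.3-fold higher number from compound 1 to compound 2 (0.12 log units; within the scatter), the step from compound 3 to compound 4 is expected to be about a 1.3-fold higher number from compound 3 to compound 4 (0.12 log units; within the scatter). Compound 4 is therefore estimated at 9000 nM, between 4500 nM and 18000 nM.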

Compound 4, half-maximal inhibitory concentration: 11100 nM
Compound 4: middle estimate off by 1.2-fold (0.09 log units), on the low side; low and high end bracket the measured number.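

In this assay, putting oxolan-3-yl in place of methyl on the oxygen on the aromatic ring gives a 1.6-fold higher number from compound 3 to compound 4 (0.21 log units; within the scatter). Set beside the earlier step, the change carries over from one core to the other with no difference that can be told apart: the same change on two cores in this assay, a 1.3-fold higher number (0.12 log units; within the scatter) from compound 1 to compound 2 and a 1.6-fold higher number (0.21 log units; within the scatter) from compound 3 to compound 4, 1.2-fold (0.09 log units) apart, within the scatter of two such steps

This holds for these two cores only and says nothing about a further core, and as each step lies within the scatter, neither shows that the change has a real effect on this read-out.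

The compounds shown leave open whether a different group on that oxygen, such as a longer alkyl chain or a chain ending in an amine, would move the number beyond the scatter. They also leave open how the mirror-image form of the oxolan-3-yl group would behave.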